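Cytotoxicity notes on the benzimidazole-linked anilide series

The source may hold more compounds than are shown below. What is called first, only, known or untested is meant among the compounds shown, and "the series" means these compounds.

Measured so far in an ADME assay on MT4 cells (Homo sapiens) for cytotoxicity, read by MTT assay, with a stated time of 96 h; a higher number here means that more compound is tolerated, a lower number that less compound is tolerated:
- compound 1 `CN1CCN(CC(=O)Nc2ccc(-c3nc4cc(C(F)(F)F)ccc4n3C)cc2)CC1`: 22000 nM
- compound 2 `Cn1c(-c2ccc(NC(=O)CN3CCCC3)cc2)nc2cc(C(F)(F)F)ccc21`: 16000 nM
- compound 3 `CC(=O)Nc1ccc(-c2nc3cc([N+](=O)[O-])ccc3[nH]2)cc1`: > 100000 nM (a limit of the assay, not a number)

Compound 2 gives the lowest of the two numbers in this assay, with compound 1 within the scatter of it, as the step of a 1.4-fold lower number from compound 1 to compound 2 (0.14 log units; within the scatter) shows. Compound 4 `Cn1c(-c2ccc(N)cc2)nc2cc(C(F)(F)F)ccc21` differs from compound 2 by hydrogen in place of ((pyrrolidin-1-yl)methyl)carbonyl on a nitrogen on an aromatic ring. Within the data shown here, no measured step covers loss of the whole chain; the only measured step exchanges one ring for another at its end and stays within the scatter. The expected step of a 1.9-fold higher number from compound 2 to compound 4 (0.27 log units; within the scatter) is therefore small and uncertain, leaning to a higher number. Compound 4 is estimated at 30000 nM, between 10000 nM and 100000 nM.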

Compound 4, half-maximal cytotoxic concentration: 20000 nM
The estimate for compound 4 lay 1.5-fold (0.18 log units) above the measured number; the range from low to high includes it.
By their numbers in this assay, from the lowest: compounds 2, 4 and 1 (each within the scatter of the next). At a limit, above all of these: compound 3.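

In this assay, hydrogen in place of the whole chain on the nitrogen on the aromatic ring gives no step beyond the scatter: a 1.3-fold higher number from compound 2 to compound 4 (0.10 log units; within the scatter), and a 1.1-fold lower number from compound 1 to compound 4 (0.04 log units; within the scatter). The earlier step exchanged only the ring at the chain's end, whereas compound 4 shows that the number stays within the scatter with neither ((pyrrolidin-1-yl)methyl)carbonyl nor ((4-methylpiperazin-1-yl)methyl)carbonyl present. Nothing shown gives a cause for this result.

It remains open whether a longer chain on this nitrogen, or a morpholine at the chain's end, would stay within the scatter of these compounds.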